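This account rests on a few compounds, and the source may have more. Where it says the series, first, only, none or still open, it means among the compounds named here.

Compound 1 `COc1cc(-c2ccnc3cc(-c4cccc(C#N)c4)nn23)cc(OC)c1OC`: > 10000 nM (a limit, not a number)
Compound 2 `COc1cc(-c2ccnc3cc(-c4ccc(C(C)=O)cc4)nn23)cc(OC)c1OC`: 4100 nM

Within the data shown here, in a functional assay on A549 cells (Homo sapiens) for inhibition, read by CCK-8 assay, with a stated time of 48 h (on this read-out higher numbers stand for weaker inhibition and lower numbers for stronger inhibition), compound 2 gives 4100 nM, the only true number so far. Compound 1 gives > 10000 nM, which is a limit of the assay. Compound 3 `COc1ccc(-c2cc3nccc(-c4cc(OC)c(OC)c(OC)c4)n3n2)cc1F` has 3-fluoro-4-methoxyphenyl in place of 4-acetylphenyl on an aromatic carbon. Among the measured compounds shown here, the one measured step is an at least 2.4-fold lower number from compound 1 to compound 2 (0.38 log units; beyond the scatter), and it changes the group on the same carbon. From the compounds shown here alone, its full size is unknown, as one end is the limit, (the limit of > 10000 nM in this assay, at which 1 of the 2 values shown sits). That step shows this assay responding to this group, but it gives no direct measure of the new one. A step of a 10-fold lower number from compound 2 to compound 3 (1.01 log units; beyond the scatter) is expected, with wide uncertainty. For compound 3 the estimated value is 400 nM, with an expected range of 20 nM to 6000 nM.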

Compound 3, half-maximal inhibitory concentration: 545 nM
The estimate for compound 3 lay 1.4-fold (0.13 log units) below the measured number; the range from low to high includes it.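

At this aromatic carbon of the five-membered ring, this assay now gives a step between two true numbers, not one against a limit: a 7.5-fold lower number from compound 2 to compound 3 (0.88 log units; beyond the scatter). The entering 3-fluoro-4-methoxyphenyl and the leaving 4-acetylphenyl have equal heavy-atom, donor and acceptor counts, so those counts do not separate the two groups, and the step tracks the identity of the group rather than these counts. The wider step, an at least 18-fold lower number from compound 1 to compound 3 (1.26 log units; beyond the scatter), has a limit at one end and its full size stays unread: the limit of > 10000 nM in this assay, at which 1 of the 3 values shown sits.

From the compounds shown here alone, the fluorine and the methoxy enter together, so their separate shares in the step remain open. A plain 4-methoxyphenyl or 3-fluorophenyl would divide them, and a 4-aminophenyl would test an amine at the same carbon.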